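The source may report more compounds than this note shows. Statements on the series, on what has been measured and on what is new or still open speak of the compounds shown alone.

The series shares the core seen in compound 1 `CC(C)c1onc(-c2c(Cl)cccc2Cl)c1COc1ccc(N(C)C(=O)c2ccc(C(=O)O)cc2)c(C(F)(F)F)n1` and varies the group on the ring nitrogen. In a functional assay on HEK293 cells for agonist activity at Bile acid receptor (Homo sapiens), read by a luciferase reporter (on this read-out lower numbers stand for smaller maximal responses and higher numbers for larger maximal responses), compound 1 gives 63%. Compound 2 `CC(C)c1onc(-c2c(Cl)cccc2Cl)c1COc1ccc(NC(=O)c2ccc(C(=O)O)cc2)c(C(F)(F)F)n1` carries the amide with hydrogen on its nitrogen and gives 48% in this assay; compound 3 `Cc1cc(OCc2c(-c3c(Cl)cccc3Cl)noc2C(C)C)ncc1[N+](=O)[O-]`, with a different substitution on that side of the core, gives 76%. Compound 2 thus stands lowest of the three numbers, with compound 1 nearest and compound 3 furthest, both separations beyond the scatter. Within the data shown here, the one step measured between compounds differing in a single place, a number 15 percentage points lower from compound 1 to compound 2 (beyond the scatter), concerns hydrogen in place of methyl on the amide nitrogen and leaves the carbonyl untouched. Compound 4 `CC(C)c1onc(-c2c(Cl)cccc2Cl)c1COc1ccc(NCc2ccc(C(=O)O)cc2)c(C(F)(F)F)n1` differs from compound 2 by 4-carboxybenzyl in place of (4-carboxyphenyl)carbonyl on a nitrogen on an aromatic ring; the carbonyl falls away while the 4-carboxyphenyl part is kept. Among the measured compounds shown here, no measured step covers this loss of the carbonyl, so the earlier step offers only a sense of scale: a change at this nitrogen moved this assay by a modest amount beyond the scatter. Compound 3 shows that the core tolerates another group on that side with a higher number. The expectation for compound 4 is therefore a small rise that may stay within the scatter, a number 7 percentage points higher from compound 2 to compound 4 (within the scatter). Compound 4 is estimated at 55%, with a range from 35% to 75%.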

Compound 4, largest response reached (reported as efficacy), in percent of the reference or control that the assay uses: 45%
The estimate for compound 4 lay 10 percentage points above the measured number; low and high end bracket the measured number.
By their numbers in this assay, from the lowest: compounds 4 and 2 (each within the scatter of the next); then compound 1; then compound 3.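

In this assay, 4-carboxybenzyl in place of (4-carboxyphenyl)carbonyl on a nitrogen on an aromatic ring gives a number 3 percentage points lower from compound 2 to compound 4 (within the scatter), so this read-out does not separate the two compounds. The earlier step at this nitrogen changed only the hydrogen or methyl on the amide, whereas this one removes the carbonyl and keeps the 4-carboxyphenyl part, showing that in this pair the maximal response does not depend on that carbonyl. No data at hand bear on the reason for this result.

Still open, from the compounds shown here alone, is whether a methyl on the nitrogen of the (4-carboxybenzyl)amino group would act as it does on the amide nitrogen, and whether a sulfonyl in place of the carbonyl or a longer chain such as 2-(4-carboxyphenyl)ethyl would keep the response at this level. Also open, going by these compounds, is how far the response rests on the carboxylic acid itself, which a methyl ester, a tetrazole or a nitrile in its place on the benzyl group would test.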